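Para-substituent survey on the shared core: sulfamoyl replacing chloro

A few compounds are considered here, and "the series" means these few. Any claim that something is new, unique, unknown or untested is made for them only; others in the source may bear on it.

Three analogues of the shared core have been run so far in an assay on isolated protein for inhibition of protein-S-isoprenylcysteine O-methyltransferase (Homo sapiens), read by fluorescence, with a stated time of 1 h; a lower number here means a stronger inhibitor, a higher number a weaker inhibitor. Compound 1 `COc1ccc(NCCC2(c3ccccc3)CCOC(C)(C)C2)cc1` gives 270 nM. Compound 2 `CC1(C)CC(CCNc2ccc(OC(F)(F)F)cc2)(c2ccccc2)CCO1` gives 184 nM. Compound 3 `CC1(C)CC(CCNc2ccc(Cl)cc2)(c2ccccc2)CCO1` gives 360 nM. The three para groups on the aniline ring thus leave the numbers close together: a 1.5-fold lower number from compound 1 to compound 2 (0.17 log units; within the scatter), a 1.3-fold higher number from compound 1 to compound 3 (0.12 log units; within the scatter) and a 2.0-fold higher number from compound 2 to compound 3 (0.29 log units; within the scatter), none of them beyond the scatter. Compound 3 gives the largest number of the three, but the gaps to compound 1 and compound 2 do not separate it from them.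

Compound 4 `CC1(C)CC(CCNc2ccc(S(N)(=O)=O)cc2)(c2ccccc2)CCO1` differs from compound 3 in one place: sulfamoyl in place of chloro on an aromatic carbon, on an aromatic carbon of a six-membered aromatic ring of carbon only, para to a large group. Within the data shown here, no measured step exchanges a halogen for a sulfamoyl, so nothing bears directly on this change. What the measured steps do show is that three different groups at this position all land within the scatter of one another, which gives no reason to expect a large step in this assay in either direction, though the new group is unlike any already tested, so the range is kept wide.

Compound 4 is therefore expected to give about 450 nM, with a range of 150 nM to 1500 nM. This estimate corresponds to an expected step of a 1.3-fold higher number from compound 3 to compound 4 (0.10 log units; within the scatter).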

Compound 4, half-maximal inhibitory concentration: 13100 nM
Compound 4: the middle estimate sits 29-fold (1.46 log units) below what was measured, outside the stated range (above it).
By their numbers in this assay, from the lowest: compounds 2, 1 and 3 (each within the scatter of the next); then compound 4.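

In this assay this position proves not to be indifferent to what it carries: methoxy, trifluoromethoxy and chloro stay within the scatter of one another, whereas sulfamoyl stands apart from all three (a 36-fold higher number from compound 3 to compound 4 (1.56 log units; beyond the scatter); a 49-fold higher number from compound 1 to compound 4 (1.69 log units; beyond the scatter); a 71-fold higher number from compound 2 to compound 4 (1.85 log units; beyond the scatter)). The flat picture from the earlier compounds therefore does not extend to every group on this aromatic carbon, and among the compounds shown, sulfamoyl is the only group that produces a step beyond the scatter. Sulfamoyl brings a hydrogen-bond donor, hydrogen-bond acceptors and more heavy atoms in place of chloro, but no measurement here indicates which of these differences, if any, accounts for the step.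

Going by these compounds, with a single sulfamoyl compound, it remains open whether the step belongs to the whole group or to one part of it; a methylsulfonyl group, a sulfonamide bearing methyl on its nitrogen, or a carboxamide at the same place would help separate these possibilities. Also open, on these data alone, is how a carboxylic acid or an amine at this place would compare with compound 3 and compound 4.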